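A Methoxy Added to Compound 1 at a Different Place

The compounds below may be only part of what the source reports. "The series", "measured", "known", "first", "only" and "open" are said of these compounds alone.

Compound 1 `CC(=O)N1N=C2N(N=C(Cc3ccccc3)C(=O)N2N(C(C)=O)C(C)=O)C1c1ccccc1` stands second highest of the three numbers in an assay on microsomes from liver for inhibition of cytochrome P450 1A1 (Rattus norvegicus), read by fluorescence, with a stated time of 10 min (on this read-out lower numbers stand for stronger inhibition and higher numbers for weaker inhibition), at 24.2 nM. Its nearest neighbour is compound 3 `CC(=O)NN1C(=O)C(Cc2ccccc2)=NN2C1=NN(C(C)=O)C2(C)c1ccccc1` with 13.2 nM, a gap within the usual scatter; the furthest is compound 2 `COc1ccc(CC2=NN3C(=NN(C(C)=O)C3c3ccccc3)N(N(C(C)=O)C(C)=O)C2=O)cc1` with 86.7 nM. Compound 4 `COc1ccc(C2N(C(C)=O)N=C3N2N=C(Cc2ccccc2)C(=O)N3N(C(C)=O)C(C)=O)cc1` carries methoxy in place of hydrogen on an aromatic carbon, placed on a six-membered aromatic ring of carbon only, para to a large group; cut one bond further out, the change reads phenyl to 4-methoxyphenyl. Among the measured compounds shown here, the one measured step that bears on it is a 3.6-fold higher number from compound 1 to compound 2 (0.55 log units; beyond the scatter), where the same group entered compound 1, though not at the same place. For compound 4 a weakening of similar, modest size is therefore expected, a 2.3-fold higher number from compound 1 to compound 4 (0.36 log units; beyond the scatter). Compound 4 is estimated at 55 nM, within a range of 20 nM to 150 nM.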

Compound 4, half-maximal inhibitory concentration: 9.71 nM
For compound 4 the middle estimate is 5.7-fold (0.75 log units) above the measured one, and the stated range ends above it.
By their numbers in this assay, from the lowest: compounds 4, 3 and 1 (each within the scatter of the next, the first and the last beyond it); then compound 2.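

Within this assay the change from phenyl to 4-methoxyphenyl gives a 2.5-fold lower number from compound 1 to compound 4 (0.40 log units; beyond the scatter) and so stronger inhibition, whereas methoxy at the other place gave a 3.6-fold higher number from compound 1 to compound 2 (0.55 log units; beyond the scatter) in the opposite direction. On these two steps, the direction of the methoxy change therefore depends on where in compound 1 the group enters. Nothing measured here accounts for this reversal. From the compounds shown here alone, what remains open is whether an amine or a carboxylic acid at this place would move the number in the same direction, and whether a longer chain such as ethoxy would keep the gain.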